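Series notes: 3-bromobenzyl to 4-bromobenzyl, second pair

The source may report more compounds than this note shows. Statements on the series, on what has been measured and on what is new or still open speak of the compounds shown alone.

All values below come from a functional assay on MCF7 cells (Homo sapiens) for inhibition, read by MTT assay, with a stated time of 48 h, tested at 10 uM; a lower number here means less inhibition of growth, a higher number more inhibition of growth at the concentration tested.

Measured compounds:
compound 1 `O=C(/C=C/c1ccc(OCc2cn(Cc3cccc(Br)c3)nn2)cc1)c1ccc(Br)cc1` — 36%
compound 2 `O=C(/C=C/c1ccc(OCc2cn(Cc3ccc(Br)cc3)nn2)cc1)c1ccc(Br)cc1` — 23%
compound 3 `O=C(/C=C/c1ccc(OCc2cn(Cc3cccc(Br)c3)nn2)cc1)c1ccc([N+](=O)[O-])cc1` — 12%

Compound 2 differs from compound 1 by 4-bromophenyl in place of 3-bromophenyl on a saturated chain carbon bound to an aromatic nitrogen; this change gave a number 13 percentage points lower from compound 1 to compound 2 (beyond the scatter). Compound 3 differs from compound 1 by nitro in place of bromo on an aromatic carbon, which gave a number 24 percentage points lower from compound 1 to compound 3 (beyond the scatter), leaving compound 3 lowest of the three in this assay.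

Compound 4 `O=C(/C=C/c1ccc(OCc2cn(Cc3ccc(Br)cc3)nn2)cc1)c1ccc([N+](=O)[O-])cc1` has not yet been measured in this assay. It differs from compound 3 by 4-bromophenyl in place of 3-bromophenyl on a saturated chain carbon bound to an aromatic nitrogen, the same change, at the same place, as from compound 1 to compound 2, here made on the core of compound 3.

Going by the values given here, the only guide is the one earlier instance. Among the compounds with values here, on that basis the step from compound 3 to compound 4 is expected to be of similar size, a number 9 percentage points lower from compound 3 to compound 4 (within the scatter), because a number 13 percentage points lower from compound 1 to compound 2 (beyond the scatter) is the single precedent; the starting level of compound 3 is already low, so there is little room to fall. Compound 4 is therefore expected to show about 3% in this assay, estimated between -8% and 15%.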

Compound 4, percent growth inhibition at one concentration: 18%
Estimate against measurement, compound 4: 15 percentage points below, and the stated range ends below it.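

In this assay, the change from 3-bromobenzyl to 4-bromobenzyl does not carry over from the core of compound 1 to the core of compound 3, and the two steps differ: the same change on two cores in this assay, a number 13 percentage points lower (beyond the scatter) from compound 1 to compound 2 and a number 6 percentage points higher (within the scatter) from compound 3 to compound 4, 19 percentage points apart, beyond the scatter of two such steps. On the core of compound 3 the step reads a number 6 percentage points higher from compound 3 to compound 4 (within the scatter), so 3-bromobenzyl and 4-bromobenzyl are not told apart there, and nitro in place of bromo also depends on its partner group, reading a number 5 percentage points lower from compound 2 to compound 4 (within the scatter): the same change on two cores in this assay, a number 24 percentage points lower (beyond the scatter) from compound 1 to compound 3 and a number 5 percentage points lower (within the scatter) from compound 2 to compound 4, 19 percentage points apart, beyond the scatter of two such steps. These four compounds show that the two changes do not add up simply in this set, but they do not show how either change would behave on any other core, or at any other concentration.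

Open, from the compounds shown here alone, is whether the same dependence appears with an amine or a carboxylic acid in place of nitro or bromo on the aromatic carbon. Also open, going by these compounds, is whether it survives with a longer chain in place of the bromobenzyl group.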